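This account rests on a few compounds, and the source may have more. Where it says the series, first, only, none or still open, it means among the compounds named here.

Of the compounds shown here, three built on one shared core have been tested in an ADME assay on HepG2 cells (Homo sapiens) for cytotoxicity, read by trypan blue exclusion, with a stated time of 48 h, in the presence of a further agent that is not named here; on this read-out lower numbers stand for higher toxicity in this test and higher numbers for lower toxicity in this test. Compound 1 `COc1ccc(NC(=O)COc2cc(C)nc3ccc(OC)cc23)c(OC)c1` reaches only a limit in this assay, recorded as > 131000 nM. Compound 2 `COc1ccc2nc(C)cc(OCC(=O)Nc3ccc(OC)c(OC)c3)c2c1` likewise gives only a limit in this assay, > 131000 nM. Compound 3 `COc1ccc2nc(C)cc(OCC(=O)Nc3cccc(Br)c3)c2c1` also reaches a limit in this assay, > 125000 nM. So compound 3 stands where all three measured compounds stand: at a limit rather than at a number, one value sitting at the limit of > 125000 nM in this assay, at which 1 of the 3 values shown sits, and two at the limit of > 131000 nM in this assay, at which 2 of the 3 values shown sit, so that none of the three can be set apart from the others.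

Compound 4 `COc1ccc2nc(C)cc(OCC(=O)Nc3ccc(C)cc3)c2c1` has not yet been measured in this assay. It differs from compound 3 in one place: 4-methylphenyl in place of 3-bromophenyl on an amide-type nitrogen. Among the measured compounds shown here, no pair of measured compounds differs in a single place, so no measured step is available to size this change. Since compound 3 gives only a limit, > 125000 nM, the change is expected to bring no step beyond the scatter. The step from compound 3 to compound 4 is estimated as a step that the limit leaves unreadable from compound 3 to compound 4. Compound 4 is expected to give about 150000 nM in this assay, within a range from 90000 nM to 300000 nM, most likely again as a limit.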

Compound 4, half-maximal cytotoxic concentration: > 149000 nM
Compound 4 ended at the assay's limit; the forecaster's own chance of this, stated with the estimate: 85%; the middle value lies beyond the limit too.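

Compound 3 and compound 4 each give only a limit in this assay, and the size of the step between them cannot be read. The compounds shown leave open at what concentration any of them would harm these cells, and whether the group on the amide-type nitrogen changes that.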